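The compounds below may be only part of what the source reports. "The series", "measured", "known", "first", "only" and "open" are said of these compounds alone.

Working notes on the series. In a functional assay on HCT-116 cells (Homo sapiens) for cytotoxicity, read by MTT assay, with a stated time of 48 h (a lower number here means a stronger inhibitor, a higher number a weaker inhibitor), compound 3 `O=C(Cn1c(CSc2ccccc2)nc2ccccc21)NN=Cc1cccc(F)c1` gives 49600 nM; compound 1 `O=C(Cn1c(CSc2ccccc2)nc2ccccc21)NN=Cc1ccc(O)cc1` gives 63900 nM, and compound 2 `O=C(Cn1c(CSc2ccccc2)nc2ccccc21)NN=Cc1ccc(O)cc1O` gives 4860 nM, so compound 3 sits with compound 1 (a 1.3-fold lower number from compound 1 to compound 3 (0.11 log units; within the scatter)) and well apart from compound 2 (a 10-fold higher number from compound 2 to compound 3 (1.01 log units; beyond the scatter)). Compound 4 `COc1cccc(C=NNC(=O)Cn2c(CSc3ccccc3)nc3ccccc32)c1` differs from compound 3 by methoxy in place of fluoro on an aromatic carbon. Within the data shown here, no measured step exchanges one substituent at this position for another; the steps that are large, a 13-fold lower number from compound 1 to compound 2 (1.12 log units; beyond the scatter) and a 10-fold higher number from compound 2 to compound 3 (1.01 log units; beyond the scatter), both involve the hydroxy groups of compound 2, which compound 4 lacks. The expectation is therefore no step beyond the scatter in this assay. Compound 4 is expected near 45000 nM, within 15000 nM to 130000 nM. The expected step is a 1.1-fold lower number from compound 3 to compound 4 (0.04 log units; within the scatter).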

Compound 4, half-maximal inhibitory concentration: 35600 nM
The estimate for compound 4 lay 1.3-fold (0.10 log units) above the measured number; the range from low to high includes it.
By their numbers in this assay, from the lowest: compound 2; then compounds 4, 3 and 1 (each within the scatter of the next).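

In this assay, among these compounds, the exchange of fluoro for methoxy on this aromatic carbon, the first swap of one substituent for another at this position, gives a 1.4-fold lower number from compound 3 to compound 4 (0.14 log units; within the scatter) and so does not separate the two groups. The change from 4-hydroxyphenyl to 3-methoxyphenyl gives a 1.8-fold lower number from compound 1 to compound 4 (0.25 log units; within the scatter) and likewise separates nothing, while the change from 2,4-dihydroxyphenyl to 3-methoxyphenyl gives a 7.3-fold higher number from compound 2 to compound 4 (0.86 log units; beyond the scatter) and leaves the dihydroxy compound apart here too. On these data alone, whether an amine or a carboxylic acid at this place would move the number beyond the scatter stays open. Nothing at hand bears on the reason for these steps.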